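Swapping the aryl on the triazole for a sulfamoyl variant

The source may hold more compounds than are shown below. What is called first, only, known or untested is meant among the compounds shown, and "the series" means these compounds.

Compound 1 `Cc1ccccc1-n1nncc1CN1C(=O)C2(C(C#N)=C(N)Oc3c2c2nc4ccccc4nc2c2ccccc32)c2ccccc21` gives in a functional assay on HCT-116 cells (Homo sapiens) for antiproliferative activity, read by MTT assay, with a stated time of 48 h (on this read-out higher numbers stand for weaker inhibition and lower numbers for stronger inhibition), the limit > 50000 nM.
Compound 2 `N#CC1=C(N)Oc2c(c3nc4ccccc4nc3c3ccccc23)C12C(=O)N(Cc1cnnn1-c1cccc(Cl)c1)c1ccccc12` gives in this assay the limit > 50000 nM.
Compound 3 `CCOc1ccc(-n2nncc2CN2C(=O)C3(C(C#N)=C(N)Oc4c3c3nc5ccccc5nc3c3ccccc43)c3ccccc32)cc1` gives in this assay the limit > 50000 nM.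

None of these three values is a measured number; each is a limit of the assay, and that is the whole of the evidence so far: the limit of > 50000 nM in this assay, at which 3 of the 3 values shown sit. Compound 3 therefore stands at the limit, with the two other values shown also being limits, so no order among the three compounds can be read.

The change now considered is the step from compound 3 to compound 4 `N#CC1=C(N)Oc2c(c3nc4ccccc4nc3c3ccccc23)C12C(=O)N(Cc1cnnn1-c1cccc(S(N)(=O)=O)c1)c1ccccc12`: 3-sulfamoylphenyl in place of 4-ethoxyphenyl on an aromatic nitrogen. Among the compounds with values here, three measured steps bear on it, since each swaps the aryl group on the same aromatic nitrogen of the shared core: a step that the two limits leave unreadable from compound 1 to compound 2, a step that the two limits leave unreadable from compound 1 to compound 3 and a step that the two limits leave unreadable from compound 2 to compound 3. From the compounds shown here alone, each is left unreadable by the two limits at its ends, so their size is unknown. A methyl, a chlorine and an ethoxy on that aryl ring all left the value at the limit, and a sulfamoyl group is a fourth variation at the same place. No step beyond the scatter is expected in this assay, and the expected step is a step that the limit leaves unreadable from compound 3 to compound 4. Compound 4 is therefore estimated at 60000 nM, in a range from 20000 nM to 200000 nM, most likely reported again only as a limit.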

Compound 4, half-maximal inhibitory concentration: 11300 nM
Estimate against measurement, compound 4: 5.3-fold (0.73 log units) above; the whole stated range lies above it.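

In this assay, within the data shown here, compound 4 is the only one of the four compounds with a measured number rather than a limit, and the sulfamoyl group gives the first readable steps at this position: an at least 4.4-fold lower number from compound 3 to compound 4 (0.64 log units; beyond the scatter), an at least 4.4-fold lower number from compound 2 to compound 4 (0.64 log units; beyond the scatter) and an at least 4.4-fold lower number from compound 1 to compound 4 (0.64 log units; beyond the scatter). The second of these is the most telling, as the aryl ring keeps its substituent in the same place and only chloro gives way to sulfamoyl, so the place on the ring alone does not give the lower number. The steps among compounds 1, 2 and 3 cannot be read, so the aryl group on this aromatic nitrogen is only now seen to change the read-out, and the lower number rests on one compound set against limits: the limit of > 50000 nM in this assay, at which 3 of the 4 values shown sit.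

From the compounds shown here alone, how far the true values of compounds 1, 2 and 3 lie from that of compound 4 stays open, so the full size of these steps is unknown. Also open, going by these compounds, is whether the lower number needs the sulfamoyl group itself, or whether a methylsulfonyl group, a carboxylic acid or an amine on the same ring would give a similar value.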